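The source may report more compounds than this note shows. Statements on the series, on what has been measured and on what is new or still open speak of the compounds shown alone.

Measured compounds:
compound 1, `CNC(=O)/C=C1/COc2cc(OS(=O)(=O)c3cccc(Cl)c3)ccc21`, 41 nM
compound 2, `CNC(=O)/C=C1/COc2cc(OS(=O)(=O)c3ccc(C#N)cc3)ccc21`, 45 nM
compound 3, `CNC(=O)/C=C1/COc2c1ccc(OS(=O)(=O)c1cccc(Cl)c1)c2C`, 24 nM

All three were tested in an assay (strain Sprague-Dawley) for inhibition of Amine oxidase [flavin-containing] A (Rattus norvegicus), read by spectrophotometry, with a stated time of 5 min; a lower number here means a stronger inhibitor, a higher number a weaker inhibitor. Compound 1 and compound 2 differ by 4-cyanophenyl in place of 3-chlorophenyl on a sulfonyl sulfur, and this change gave a 1.1-fold higher number from compound 1 to compound 2 (0.04 log units; within the scatter). Compound 3 shares its core with compound 1 apart from methyl in place of hydrogen on an aromatic carbon, a difference that gave a 1.7-fold lower number from compound 1 to compound 3 (0.23 log units; within the scatter).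

Compound 4, `CNC(=O)/C=C1/COc2c1ccc(OS(=O)(=O)c1ccc(C#N)cc1)c2C`, has not yet been measured in this assay. It differs from compound 3 by 4-cyanophenyl in place of 3-chlorophenyl on a sulfonyl sulfur, which is the same change as that from compound 1 to compound 2: the place of the change is described in the same words for both pairs, and the core of compound 3 differs from the core of compound 1 only by methyl in place of hydrogen on an aromatic carbon. Within the data shown here, the expectation therefore rests on the single earlier instance of the change, a 1.1-fold higher number from compound 1 to compound 2 (0.04 log units; within the scatter), transferred onto compound 3 and its value 24 nM. For compound 4 the expected step is a 1.1-fold higher number from compound 3 to compound 4 (0.05 log units; within the scatter), close to nothing, because a 1.1-fold higher number from compound 1 to compound 2 (0.04 log units; within the scatter) was itself within the scatter. Compound 4 is thus estimated at 27 nM, with a range from 12 nM to 60 nM, and the measurement will show whether the change behaves the same on this core.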

Compound 4, half-maximal inhibitory concentration: 15 nM
The estimate for compound 4 lay 1.8-fold (0.26 log units) above the measured number; low and high end bracket the measured number.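

In this assay, 4-cyanophenyl in place of 3-chlorophenyl on the sulfonyl sulfur gave a 1.6-fold lower number from compound 3 to compound 4 (0.20 log units; within the scatter), and the two cores agree on this change: the same change on two cores in this assay, a 1.1-fold higher number (0.04 log units; within the scatter) from compound 1 to compound 2 and a 1.6-fold lower number (0.20 log units; within the scatter) from compound 3 to compound 4, 1.8-fold (0.24 log units) apart, within the scatter of two such steps. Methyl in place of hydrogen on an aromatic carbon, read with 4-cyanophenyl present, gave a 3.0-fold lower number from compound 2 to compound 4 (0.48 log units; beyond the scatter), and this step also agrees with its earlier counterpart: the same change on two cores in this assay, a 1.7-fold lower number (0.23 log units; within the scatter) from compound 1 to compound 3 and a 3.0-fold lower number (0.48 log units; beyond the scatter) from compound 2 to compound 4, 1.8-fold (0.24 log units) apart, within the scatter of two such steps. Both changes therefore carried from one core to the other without a difference that can be told from the scatter, but these four compounds form a single square of two cores and two groups, so they do not show that either change would carry to other cores, or why the numbers move as they do.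

The compounds shown leave open how the number would respond if an amine or a carboxylic acid stood on the phenyl ring, or if a butyl chain replaced that ring on the sulfonyl sulfur. They also leave open whether an ethyl or a methoxy group would behave like methyl on the aromatic carbon.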